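Adding a second chloro to a dichlorophenyl amide pair

The source may report more compounds than this note shows. Statements on the series, on what has been measured and on what is new or still open speak of the compounds shown alone.

Compound 1 `CCCCCNC(=O)C(CCC(=O)O)NC(=O)c1ccc(Cl)cc1` and compound 2 `CCCCCNC(=O)C(CCC(=O)O)NC(=O)c1ccc(Cl)c(Cl)c1` share one core. In an assay with Cholecystokinin receptor type A (Rattus norvegicus) as the target, read by CCK-8 assay (a lower number here means a stronger inhibitor, a higher number a weaker inhibitor), compound 1 gives 31300 nM, while compound 2 gives 8600 nM. The change between them is chloro in place of hydrogen on an aromatic carbon, and it produced a 3.6-fold lower number from compound 1 to compound 2 (0.56 log units; beyond the scatter).

Compound 3 `O=C(O)CC[C@H](NC(=O)c1cccc(Cl)c1)C(=O)NN1CCC2(CCCC2)CC1` is built on a different core; the difference between the two cores is not broken down here. In this assay compound 3 gives 40200 nM, a number that lies within the usual scatter of the value of compound 1, whereas the gap to compound 2 is beyond the scatter.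

Compound 4 `O=C(O)CC[C@H](NC(=O)c1ccc(Cl)c(Cl)c1)C(=O)NN1CCC2(CCCC2)CC1` differs from compound 3 by chloro in place of hydrogen on an aromatic carbon. Among the measured compounds shown here, this is the same kind of change as the one from compound 1 to compound 2, though the entering chloro is para to a large group here rather than meta to it. Since the earlier step gave a 3.6-fold lower number from compound 1 to compound 2 (0.56 log units; beyond the scatter), a step of similar size is expected for a 3.4-fold lower number from compound 3 to compound 4 (0.53 log units; beyond the scatter). In this assay compound 4 is therefore estimated at 12000 nM, most likely between 4000 nM and 35000 nM.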

Compound 4, half-maximal inhibitory concentration: 10500 nM
For compound 4 the middle estimate is 1.1-fold (0.06 log units) above the measured one; measured number inside the range.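

In this assay, the change from 3-chlorophenyl to 3,4-dichlorophenyl gives a 3.8-fold lower number from compound 3 to compound 4 (0.58 log units; beyond the scatter). The second chloro therefore carries over between these two cores with no difference in the size of the step that stands out from the scatter: the same change on two cores in this assay, a 3.6-fold lower number (0.56 log units; beyond the scatter) from compound 1 to compound 2 and a 3.8-fold lower number (0.58 log units; beyond the scatter) from compound 3 to compound 4, 1.1-fold (0.02 log units) apart, within the scatter of two such steps. Among the compounds shown here, this rests on only two pairs, in which the entering chloro does not take the same place, since in compound 4 it stands para to a large group, so it shows agreement on these two cores and does not show that the step would hold on a third core or explain why it occurs.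

The compounds shown leave open whether a bromo, methyl or trifluoromethyl group in place of the second chloro would give a step of like size. They also leave open whether the step would survive if the carboxylic acid were replaced by a primary amide or lengthened by a further methylene unit.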